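The compounds below may be only part of what the source reports. "The series", "measured", "known", "first", "only" and "open" are said of these compounds alone.

Within the data shown here, in a functional assay on A2780 cells (Homo sapiens) for cytotoxicity, read by MTT assay, with a stated time of 72 h (a lower number here means a stronger inhibitor, a higher number a weaker inhibitor), compound 1 `Cc1cc(C)cc(C(=O)N(CCCCCC(=O)Nc2ccccc2N)CC(=O)NC2CCCCC2)c1` gives 42000 nM, the highest of the three numbers measured so far. Compound 3 `Nc1ccccc1NC(=O)CCCCCN(CC(=O)NC1CCCCC1)C(=O)c1cccc2ccccc12` gives 18100 nM. Compound 2 `Cc1cc(C)cc(C(=O)N(CC(=O)NCc2ccccc2)Cc2ccc(C(=O)Nc3cc(F)ccc3N)cc2)c1` also bears benzyl on an amide-type nitrogen but differs from compound 1 elsewhere too. Compound 2 gives 5400 nM. Compound 4 `Cc1cc(C)cc(C(=O)N(CCCCCC(=O)Nc2ccccc2N)CC(=O)NCc2ccccc2)c1` changes one place in compound 1: benzyl in place of cyclohexyl on an amide-type nitrogen, (benzyl in place of cyclohexyl on an amide-type nitrogen). Among the measured compounds shown here, no measured step covers this exact change. The nearest guide is a 2.3-fold lower number from compound 1 to compound 3 (0.37 log units; beyond the scatter), made at a different place, on a carbonyl carbon. The low value of compound 2, 5400 nM, gives only loose support. A similarly modest step towards a lower number is therefore expected, a 2.1-fold lower number from compound 1 to compound 4 (0.32 log units; beyond the scatter). The estimate for compound 4 is 20000 nM, with an expected range from 8000 nM to 50000 nM.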

Compound 4, half-maximal inhibitory concentration: 20900 nM
Compound 4: the middle estimate sits 1.0-fold (0.02 log units) below what was measured, and the stated range covers the measured number.
By their numbers in this assay, from the lowest: compound 2; then compounds 3, 4 and 1 (each within the scatter of the next, the first and the last beyond it).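

In this assay, benzyl in place of cyclohexyl on the amide-type nitrogen gives a 2.0-fold lower number from compound 1 to compound 4 (0.30 log units; within the scatter). Among these compounds, this is the first one-place comparison at this position, and it shows that an aromatic ring of carbon can replace a non-aromatic one here with no difference that stands clear of the scatter. No supporting measurement bears on this result. The compounds shown leave open whether phenethyl, a longer chain carrying the ring, or a benzyl group bearing an amine or a carboxylic acid would give a number beyond the scatter. They also leave open whether the same change behaves alike with naphthalen-1-yl on the carbonyl carbon.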